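Dropping the nitro group from a sugar-linked enone

The compounds below may be only part of what the source reports. "The series", "measured", "known", "first", "only" and "open" are said of these compounds alone.

Within the data shown here, the two compounds measured so far share a sugar-like core carrying a ketone-containing side chain. Compound 1 `CCOC(=O)C(C(=O)OCC)C(CC(=O)C[C@@H]1O[C@H](CO)[C@@H](O)[C@H](O)[C@H]1O)c1ccc(Cl)cc1` has a branched, ester-bearing chain ending in a chlorinated aromatic ring, while compound 2 `O=C(/C=C/c1cccc([N+](=O)[O-])c1)C[C@@H]1O[C@H](CO)[C@@H](O)[C@H](O)[C@H]1O` carries a shorter, unsaturated chain ending in a nitro-substituted aromatic ring. In an assay for inhibition of glucose-6-phosphatase catalytic subunit 1 (Rattus norvegicus), tested at 100 uM (on this read-out lower numbers stand for less inhibition and higher numbers for more inhibition at the one concentration tested (going by the name of the read-out)), compound 1 gives -6%, and in this assay compound 2 gives 8%. Compound 2 thus stands as the higher of the two numbers, and the gap to compound 1 lies beyond the usual scatter, although both numbers sit close to no inhibition at all.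

Compound 3 `O=C(/C=C/c1ccccc1)C[C@@H]1O[C@H](CO)[C@@H](O)[C@H](O)[C@H]1O` keeps the whole of compound 2 except for one change: hydrogen in place of nitro on an aromatic carbon. Among the measured compounds shown here, no pair differing in a single place has yet been measured, so the size of this step can only be guessed. Because compound 2 shows only 8%, little room remains for a fall, and a gain seems just as uncertain. The step from compound 2 to compound 3 is expected to be a number 5 percentage points lower from compound 2 to compound 3 (within the scatter), not beyond the scatter. Compound 3 is estimated at 3%, with a likely range from -12% to 18%.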

Compound 3, a percentage reported as inhibition, at one concentration (the size of the read-out at that concentration, not a potency): -49.7%
Compound 3: middle estimate off by 52.7 percentage points, on the high side, and the stated range ends above it.
By their numbers in this assay, from the lowest: compound 3; then compound 1; then compound 2.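

In this assay, among these compounds, hydrogen in place of nitro on an aromatic carbon gives a number 57.7 percentage points lower from compound 2 to compound 3 (beyond the scatter), the first step that can be read from a single change. It shows that this place on the six-membered aromatic ring is not a neutral spot, since the read-out moves strongly with what sits there, even though compound 2 at 8% shows little inhibition to begin with. Compound 3 lands at -49.7%, well below zero rather than merely near it, so losing the nitro group does more than remove a small inhibition, and nothing available here accounts for the size of this fall.

A single pair cannot tell whether the nitro group itself matters or whether any other group at this place would lift the number in the same way, and an amine, a nitrile or a carboxylic acid in that spot would begin to separate these two readings. On these data alone, what a number this far below zero means at the one concentration tested also stays open, as does whether nitro elsewhere on the ring would give a similar value.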